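Swapping the pyrrolyl group on the shared core

The compounds below may be only part of what the source reports. "The series", "measured", "known", "first", "only" and "open" are said of these compounds alone.

Measured compounds:
compound 1 `Cc1nn(C)c(-n2cccc2)c1/C=N/OCc1ccc(C(=O)OC(C)(C)C)cc1`: 24.9 ug/mL
compound 2 `Cc1nn(C)c(Sc2ccccc2)c1/C=N/OCc1ccc(C(=O)OC(C)(C)C)cc1`: 4.91 ug/mL

In a functional assay on SK-MEL-2 cells (Homo sapiens) for cytotoxicity (a lower number here means a stronger inhibitor, a higher number a weaker inhibitor), compound 1 gives 24.9 ug/mL, the highest of the two numbers recorded; its nearest neighbour is compound 2, and the change a 5.1-fold lower number from compound 1 to compound 2 (0.71 log units; beyond the scatter) came with phenylsulfanyl in place of 1H-pyrrol-1-yl on an aromatic carbon of the shared core. Compound 3 `Cc1nn(C)c(N(C)C)c1/C=N/OCc1ccc(C(=O)OC(C)(C)C)cc1` is not yet measured. It differs from compound 1 by dimethylamino in place of 1H-pyrrol-1-yl on an aromatic carbon. Among the measured compounds shown here, no measured step replaces the 1H-pyrrol-1-yl with dimethylamino; the only step at this position, from compound 1 to compound 2, introduces a different group, so it bears on compound 3 only loosely. From the compounds shown here alone, a change at this same position did move this assay, but the direction for a dimethylamino group remains open. Compound 3 is therefore expected to stay near compound 1, with a 1.2-fold lower number from compound 1 to compound 3 (0.10 log units; within the scatter), giving an estimated 20 ug/mL within a range of 6 ug/mL to 60 ug/mL.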

Compound 3, half-maximal inhibitory concentration: 23.9 ug/mL
Compound 3: middle estimate off by 1.2-fold (0.08 log units), on the low side, and the stated range covers the measured number.
By their numbers in this assay, from the lowest: compound 2; then compounds 3 and 1 (each within the scatter of the next).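

In this assay, dimethylamino in place of 1H-pyrrol-1-yl gives a 1.0-fold lower number from compound 1 to compound 3 (0.02 log units; within the scatter), so at this position a group with no ring and 3 heavy atoms reads the same as one with a five-membered aromatic ring and 5 heavy atoms. Dimethylamino in place of phenylsulfanyl gives a 4.9-fold higher number from compound 2 to compound 3 (0.69 log units; beyond the scatter), which leaves compound 2 alone at the lower number, while the two groups attached through nitrogen stay together at the higher one. Nothing measured here explains this difference.

From the compounds shown here alone, what remains open is whether the lower number of compound 2 goes with the sulfur link, the phenyl ring, or both. A phenoxy group or an anilino group at this position would help separate these, and a methylsulfanyl group would test the sulfur link without the phenyl ring.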